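A few compounds are considered here, and "the series" means these few. Any claim that something is new, unique, unknown or untested is made for them only; others in the source may bear on it.

Measured compounds:
compound 1, `O=[N+]([O-])c1ccc2c(c1)CCN(c1ncnc3c1ncn3[C@@H]1O[C@H](CO)[C@@H](O)[C@H]1O)C2`, 182 nM
compound 2, `OC[C@H]1O[C@@H](n2cnc3c(CSc4c(F)cccc4Cl)ncnc32)[C@H](O)[C@@H]1O`, 1510 nM

In an assay on isolated protein for binding affinity to Equilibrative nucleoside transporter 1 (Homo sapiens) (on this read-out lower numbers stand for stronger inhibition and higher numbers for weaker inhibition), compound 2 gives 1510 nM, the highest of the two numbers; the nearest is compound 1 at 182 nM, a gap beyond the scatter. Among the measured compounds shown here, no single-change step between measured compounds is available, so the series gives no direct guide for a ring swap on the sulfur.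

Compound 3, `N#Cc1ccc(SCc2ncnc3c2ncn3[C@@H]2O[C@H](CO)[C@@H](O)[C@H]2O)cc1`, differs from compound 2 in one place:
4-cyanophenyl in place of 2-chloro-6-fluorophenyl on a sulfur

The change keeps the same kind of ring on the sulfur and exchanges only its substituents. For the measured compounds named here, with no comparable step to draw on, the expected step from compound 2 to compound 3 is a 1.3-fold higher number from compound 2 to compound 3 (0.12 log units; within the scatter), estimated as small and not clearly beyond the scatter, with some lean toward a weaker number. Compound 3 is therefore estimated at 2000 nM in this assay, within a range from 500 nM to 8000 nM.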

Compound 3, half-maximal inhibitory concentration: 81.3 nM
Estimate against measurement, compound 3: 25-fold (1.39 log units) above; the measured number lies below the stated range.
By their numbers in this assay, from the lowest: compound 3; then compound 1; then compound 2.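

In this assay the ring on the sulfur proves to be a sensitive point: 4-cyanophenyl in place of 2-chloro-6-fluorophenyl gives a 19-fold lower number from compound 2 to compound 3 (1.27 log units; beyond the scatter), even though the ring type and the heavy-atom count of the group stay the same. The position therefore responds strongly to the substituents on this ring, a point compound 1 cannot address, as it differs from both compounds in more than one place. No measurement at hand bears on the cause of this step.

This single step removes chlorine and fluorine and adds the nitrile together, so it cannot show which of these changes accounts for the difference. Also open, on these data alone, is how the position responds to an unsubstituted phenyl, or to an amine or a carboxylic acid on the ring.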